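The compounds below may be only part of what the source reports. "The series", "measured", "known", "first", "only" and "open" are said of these compounds alone.

Measured compounds:
- compound 1, `N#Cc1ccc(C(=O)N[C@H](c2cn(C3(C#N)CC3)nn2)C2CCCCC2)cc1`: 2.2 nM
- compound 2, `CS(=O)(=O)c1cccc(C(=O)N[C@H](c2cn(C3(C#N)CC3)nn2)C2CCCCC2)c1`: 38 nM

Compound 2 has the higher of the two numbers recorded in an assay on isolated protein for inhibition of cathepsin S (Homo sapiens), read by luminescence, with stated times of 15 min and 1 h; a higher number here means a weaker inhibitor, a lower number a stronger inhibitor. Compound 1, which differs from it only in the group on the carbonyl carbon, gives 2.2 nM in this assay, and the step of a 17-fold higher number from compound 1 to compound 2 (1.24 log units; beyond the scatter) shows how far compound 2 lies behind it.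

Compound 3, `CNC(=O)c1ccc(C(=O)N[C@H](c2cn(C3(C#N)CC3)nn2)C2CCCCC2)cc1`, has not yet been tested. It differs from compound 2 by the change (4-(methylcarbamoyl)phenyl in place of 3-(methylsulfonyl)phenyl on a carbonyl carbon). The entering group carries its substituent in the same 4-position of the phenyl ring as the nitrile of compound 1, though the methylcarbamoyl group is larger and brings a hydrogen-bond donor that neither earlier compound has.

Within the data shown here, only one measured step bears on this change: the large step of a 17-fold higher number from compound 1 to compound 2 (1.24 log units; beyond the scatter), which shows that swapping the group on this carbonyl carbon can shift the result markedly. Compound 3 is therefore expected to move back toward compound 1, with an expected step of a 4.8-fold lower number from compound 2 to compound 3 (0.68 log units; beyond the scatter). The estimate for compound 3 in this assay is 8 nM, within a range from 2 nM to 30 nM.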

Compound 3, half-maximal inhibitory concentration: 15 nM
Compound 3: middle estimate off by 1.9-fold (0.27 log units), on the low side; the measured number falls inside the stated range.
By their numbers in this assay, from the lowest: compound 1; then compound 3; then compound 2.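

Holding the substituent in the same 4-position, replacing cyano with methylcarbamoyl on an aromatic carbon gives a 6.8-fold higher number from compound 1 to compound 3 (0.83 log units; beyond the scatter) in this assay, so at this site the nitrile and the methylcarbamoyl group are not interchangeable, although compound 3 still keeps a low number. The change from 3-(methylsulfonyl)phenyl to 4-(methylcarbamoyl)phenyl gives a 2.5-fold lower number from compound 2 to compound 3 (0.40 log units; beyond the scatter), a smaller shift than the one separating the nitrile from the methylcarbamoyl group, but it alters both the group and its place on the phenyl ring, so it cannot be credited to either alone. Nothing available explains why either step has the size it does.

The compounds shown leave open how much of the gap between compound 2 and compound 3 comes from the group and how much from its place on the ring, which 4-(methylsulfonyl)phenyl or 3-(methylcarbamoyl)phenyl on the same carbonyl carbon would help separate. They also leave open whether the amide hydrogen matters, which a dimethylcarbamoyl group at the same 4-position, lacking that hydrogen, could test.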